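The compounds below may be only part of what the source reports. "The series", "measured", "known", "first", "only" and "open" are said of these compounds alone.

Measured compounds:
Compound 1, `Cc1cn([C@@H]2O[C@H](CO[Si](C)(C)C(C)(C)C)[C@@]3(OS(=O)(=O)C=C3NC(=O)c3ccccc3)[C@H]2O[Si](C)(C)C(C)(C)C)c(=O)n(C)c1=O`: >= 3200 nM
Compound 2, `COC(=O)CCNC1=CS(=O)(=O)O[C@@]12[C@@H](CO[Si](C)(C)C(C)(C)C)O[C@@H](n1cc(C)c(=O)n(C)c1=O)[C@@H]2O[Si](C)(C)C(C)(C)C`: >= 400000 nM
Compound 3, `C=C(C)C(=O)NC(=O)NC1=CS(=O)(=O)O[C@@]12[C@@H](CO[Si](C)(C)C(C)(C)C)O[C@@H](n1cc(C)c(=O)n(C)c1=O)[C@@H]2O[Si](C)(C)C(C)(C)C`: 20000 nM

In a functional assay on HEL cells (Homo sapiens) for cytotoxicity, read by microscopy (on this read-out lower numbers stand for higher toxicity in this test and higher numbers for lower toxicity in this test), compound 1 stands at a limit of the assay, >= 3200 nM, not at a number. Compound 2 also sits at a limit, >= 400000 nM. Compound 3 gives a number, 20000 nM. Of the three steps between them, two cannot be sized: a step that the two limits leave unreadable from compound 1 to compound 2 and a step that the limit leaves unreadable from compound 1 to compound 3. Among the measured compounds shown here, the one readable step is large: an at least 20-fold lower number from compound 2 to compound 3 (1.30 log units; beyond the scatter).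

Compound 4, `COC(=O)NC1=CS(=O)(=O)O[C@@]12[C@@H](CO[Si](C)(C)C(C)(C)C)O[C@@H](n1cc(C)c(=O)n(C)c1=O)[C@@H]2O[Si](C)(C)C(C)(C)C`, differs from compound 1 in one place: methoxy in place of phenyl on a carbonyl carbon. For the measured compounds named here, no measured step swaps phenyl for methoxy on that carbonyl carbon, so none bears on it directly. Both neighbours of compound 1 that keep an amide-type nitrogen with a small substituent on the carbonyl side, compound 1 itself and compound 2, read only as limits, so the step that the limit leaves unreadable from compound 1 to compound 4 is expected to be small or not readable in this assay. Compound 4 is therefore expected to come out near 50000 nM, within 3200 nM to 400000 nM.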

Compound 4, minimum cytotoxic concentration: >= 50000 nM
Compound 4 ended at the assay's limit; the forecaster's own chance of this, stated with the estimate: 70%; the middle value lies on the limit itself.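

In this assay compound 4 gives no number but rests on a limit of the assay: the limit of >= 50000 nM in this assay, at which 1 of the 4 values shown sits. On the carbonyl carbon, methoxy in place of ((1-methylethenyl)carbonyl)amino gives an at least 2.5-fold higher number from compound 3 to compound 4 (0.39 log units; beyond the scatter), so compound 3, the only one of the four with a number, now has a readable step to a second neighbour, and in both readable steps the other compound carries the higher number. The steps from compound 4 to compounds 1 and 2 cannot be read, since each joins two limits, so this result does not order methoxy against phenyl on that carbon.

Where compound 1 truly lies relative to compound 3 remains open. So does whether an ethoxy group, a longer alkoxy chain or an amine on that carbonyl carbon would give a number rather than a limit.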